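Exchanging a 4-methylpiperazin-1-yl group for an open-chain amine

A few compounds are considered here, and "the series" means these few. Any claim that something is new, unique, unknown or untested is made for them only; others in the source may bear on it.

In an ADME assay on HepG2 cells (Homo sapiens) for cytotoxicity (on this read-out higher numbers stand for lower toxicity in this test and lower numbers for higher toxicity in this test), compound 1 (`CCOC(=O)CN(C)CC#Cc1cc2ncnc(Nc3ccc(OCc4cccc(F)c4)c(Cl)c3)c2s1`) gives 26 uM and compound 2 (`CCCN(CC#Cc1cc2c(Nc3ccc(OCc4cccc(F)c4)c(Cl)c3)ncnc2s1)CCC`) gives 17 uM, two values within the scatter of each other. Compound 3 (`CN1CCN(CC#Cc2ccc3ncnc(Nc4ccc(OCc5cccc(F)c5)c(Cl)c4)c3c2)CC1`) gives 8.2 uM, the lowest of the three numbers, and the other two values both lie beyond the scatter from it. Compound 4 (`CCOC(=O)CN(C)CC#Cc1ccc2ncnc(Nc3ccc(OCc4cccc(F)c4)c(Cl)c3)c2c1`) has not yet been measured. Its structure departs from that of compound 3 by one exchange: ((ethoxycarbonyl)methyl)(methyl)amino in place of 4-methylpiperazin-1-yl on a saturated chain carbon bound to a triple-bonded carbon. This places ((ethoxycarbonyl)methyl)(methyl)amino in place of 4-methylpiperazin-1-yl on a saturated chain carbon bound to a triple-bonded carbon. Going by the values given here, no measured pair isolates this change, so the evidence is indirect. Compound 1 carries the same ((ethoxycarbonyl)methyl)(methyl)amino group on a different core and gives 26 uM. A moderate rise in this assay is therefore expected, with the estimated step being a 2.2-fold higher number from compound 3 to compound 4 (0.34 log units; beyond the scatter). The estimated value for compound 4 is 18 uM, with an expected range of 8 uM to 40 uM.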

Compound 4, half-maximal toxic concentration: > 28 uM
Compound 4: only a limit was reported (the forecaster's own chance of this, stated with the estimate: 5%); middle value at least 1.5-fold (0.19 log units) away from the limit.
By their numbers in this assay, from the lowest: compound 3; then compounds 2 and 1 (each within the scatter of the next). At a limit, above all of these: compound 4.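

Placing ((ethoxycarbonyl)methyl)(methyl)amino in place of 4-methylpiperazin-1-yl on a saturated chain carbon bound to a triple-bonded carbon gives an at least 3.4-fold higher number from compound 3 to compound 4 (0.53 log units; beyond the scatter) in this assay. Going by these compounds alone, this is the first pair that isolates the exchange, and it shows that on this core the open-chain amine goes with lower toxicity in this test than the ring. Compound 4 gives > 28 uM, which is a limit and not a number, so only the least size of the step can be read: the limit of > 28 uM in this assay, at which 1 of the 4 values shown sits.

The compounds shown do not tell whether the step follows from opening the ring or from the ethyl ester, and a carboxylic acid or a plain dimethylamino group at this place would separate the two. A 4-methylpiperazin-1-yl counterpart of compound 1 would show whether the same exchange holds on the core of compound 1.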